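Bromo to 4-methoxyphenyl on the shared core of compound 2

This account rests on a few compounds, and the source may have more. Where it says the series, first, only, none or still open, it means among the compounds named here.

Measured so far:
compound 1, `CN(C)c1nc(NNC(=O)Nc2cc(Cl)nc(Cl)c2)nc2c1ccn2C`, 58500 nM
compound 2, `O=C(Nc1cc(Cl)nc(Cl)c1)Nc1cc2ccc(Br)cn2n1`, 8940 nM

In an ADME assay on NCM460 cells (Homo sapiens) for cytotoxicity, read by MTT assay, with a stated time of 72 h, in the presence of a further agent that is not named here (a higher number here means that more compound is needed for the effect, a lower number that less compound is needed), compound 2 gives 8940 nM, the lowest of the two numbers recorded. Within the data shown here, compound 1, which shares the dichloropyridyl urea but carries a different core, gives 58500 nM, a gap beyond the scatter; no single-point step links the two compounds, so their values are only compared side by side.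

Compound 3, `COc1ccc(-c2ccc3cc(NC(=O)Nc4cc(Cl)nc(Cl)c4)nn3c2)cc1`, is not yet measured. It differs from compound 2 in one place: 4-methoxyphenyl in place of bromo on an aromatic carbon. Among the measured compounds shown here, no measured pair shows what this kind of exchange does in this assay, so the expected size of the step rests on the structure alone. A 4-methoxyphenyl in place of bromo on an aromatic carbon is expected to leave the number close to that of compound 2, with a step no larger than the scatter, and the direction is uncertain. Compound 3 is therefore estimated at 7000 nM, within a range of 2000 nM to 25000 nM, which corresponds to an expected step of a 1.3-fold lower number from compound 2 to compound 3 (0.11 log units; within the scatter).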

Compound 3, half-maximal effective concentration: 8350 nM
For compound 3 the middle estimate is 1.2-fold (0.08 log units) below the measured one, within the range that was stated.
By their numbers in this assay, from the lowest: compounds 3 and 2 (each within the scatter of the next); then compound 1.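

In this assay, among these compounds, 4-methoxyphenyl in place of bromo gives a 1.1-fold lower number from compound 2 to compound 3 (0.03 log units; within the scatter), and this is the first pair that differs in one place, so it is the first direct reading for this aromatic carbon. The carbon, two atoms from the ring nitrogen, can carry a group of 8 heavy atoms with a six-membered aromatic ring and a hydrogen-bond acceptor in place of a single bromine, with no change in the number beyond the scatter. No measurement at hand accounts for this flat step, so the pair records the outcome only.

A single exchange cannot show whether this position is insensitive to substitution in general, so an amine, a carboxylic acid or a plain phenyl on the same carbon remains an open test. As far as these compounds go, the pair also says nothing about the rest of the structure, which compound 2 and compound 3 share, and any contribution of those parts to the numbers remains untested by a one-place change.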